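Swapping Methoxy for Cyano on the Phenyl Ring

The compounds below may be only part of what the source reports. "The series", "measured", "known", "first", "only" and "open" are said of these compounds alone.

Measured so far in an assay on HEK293 cells for inhibition of SCN8A/SCN1B (Homo sapiens), read by patch clamp, with a stated time of 20 min; a higher number here means a weaker inhibitor, a lower number a stronger inhibitor:
Compound 1 `C[C@H](Nc1cc(F)c(S(=O)(=O)Nc2nccs2)cc1Cl)c1ccc(F)cc1F` gives 40 nM.
Compound 2 `C[C@H](Nc1cc(F)c(S(=O)(=O)Nc2cscn2)c(F)c1)c1ccccc1F` gives 60 nM.
Compound 3 `COc1ccc(F)c([C@H](C)Nc2cc(F)c(S(=O)(=O)Nc3cscn3)c(F)c2)c1` gives 70 nM.

All three numbers lie within the scatter of one another, so none of these compounds can be set apart as stronger or weaker; compound 3 sits at the nominally largest number, with compound 2 nearest and compound 1 furthest, both gaps inside the scatter. Going by the values given here, the one single-point change among them, a 1.2-fold higher number from compound 2 to compound 3 (0.07 log units; within the scatter), shows that adding a methoxy changed nothing beyond the scatter.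

Compound 4 `C[C@H](Nc1cc(F)c(S(=O)(=O)Nc2cscn2)c(F)c1)c1cc(C#N)ccc1F` differs from compound 3 by cyano in place of methoxy on an aromatic carbon. Among the compounds with values here, no measured pair exchanges methoxy for cyano, so the only step that bears on this change is the methoxy step from compound 2 to compound 3, which stayed within the scatter. On that basis the step from compound 3 to compound 4 in this assay is expected to be no change at the digits printed from compound 3 to compound 4 (within the scatter), not beyond the scatter in either direction. Compound 4 is therefore estimated to give 70 nM in this assay, with a range from 30 nM to 170 nM.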

Compound 4, half-maximal inhibitory concentration in the SCN8A/SCN1B assay: 140 nM
For compound 4 the middle estimate is 2.0-fold (0.30 log units) below the measured one, and the stated range covers the measured number.
By their numbers in the SCN8A/SCN1B assay, from the lowest: compounds 1, 2, 3 and 4 (each within the scatter of the next, the first and the last beyond it).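

In the SCN8A/SCN1B assay, the exchange itself gives a 2.0-fold higher number from compound 3 to compound 4 (0.30 log units; within the scatter), so methoxy and cyano cannot be told apart at this position. Set against hydrogen at the same position, however, cyano gives a 2.3-fold higher number from compound 2 to compound 4 (0.37 log units; beyond the scatter), the first single-place change in this set to pass beyond the scatter, though only modestly, and so the position is not indifferent to every group placed there. The exchange also leaves a clearly more polar compound in a physicochemical assay for lipophilicity, read by LC-MS, in phosphate buffer, measured as octanol-water partition, with a stated time of 1 h, at pH 7.4; a higher number here means a more lipophilic compound, a lower number a more polar compound: the measured distribution coefficient of compound 3, 2.9, and of compound 4, 2.2, a number 0.70 log units lower (beyond the scatter). In the physicochemical assay, compound 3 gives 2.9 and compound 4 gives 2.2.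

One pair cannot show whether inhibition at this position follows lipophilicity or depends on the particular group. Going by these compounds, an amine, a carboxylic acid or a longer chain such as ethoxy at this position might separate those two possibilities, and how far the position tolerates such groups remains open.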